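The source may hold more compounds than are shown below. What is called first, only, known or untested is meant among the compounds shown, and "the series" means these compounds.

Measured in a functional assay on RT-112 cells (Homo sapiens) for antiproliferative activity, read by MTT assay, with a stated time of 72 h; on this read-out higher numbers stand for weaker inhibition of growth and lower numbers for stronger inhibition of growth:
- compound 1 `COc1cc(Nc2ncnc3c(NC(=O)Nc4ccc(C)cc4C)cccc23)cc(OC)c1`: 1290 nM
- compound 2 `COc1cc(Nc2ncnc3c(NC(=O)Nc4cccc(Cl)c4Cl)cccc23)cc(OC)c1`: 63.2 nM
- compound 3 `COc1cc(Nc2ncnc3c(NC(=O)Nc4cccc(C)c4C)cccc23)cc(OC)c1`: 5910 nM

Compound 3 has the highest number of the three, so it inhibits growth the least. Compound 4 `COc1cc(Nc2ncnc3c(NC(=O)Nc4ccc(C(F)(F)F)cc4)cccc23)cc(OC)c1` remains unmeasured and differs from it thus: 4-(trifluoromethyl)phenyl in place of 2,3-dimethylphenyl on an amide-type nitrogen. In words, 4-(trifluoromethyl)phenyl replaces 2,3-dimethylphenyl on an amide-type nitrogen.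

Within the data shown here, no measured compound carries trifluoromethyl, so the evidence is indirect. Among the dimethylphenyl compounds, the change is modest, a 4.6-fold higher number from compound 1 to compound 3 (0.66 log units; beyond the scatter). Replacing the dimethylphenyl group with dichlorophenyl matters far more, a 94-fold higher number from compound 2 to compound 3 (1.97 log units; beyond the scatter), and a 20-fold lower number from compound 1 to compound 2 (1.31 log units; beyond the scatter). Leaving the 2,3-dimethylphenyl group is therefore expected to lower the number, though probably by less than the full gap to compound 2.

The expected change is a 15-fold lower number from compound 3 to compound 4 (1.17 log units; beyond the scatter).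

For compound 4, the estimated value is 400 nM, with an expected range of 80 nM to 2000 nM.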

Compound 4, concentration for 50% growth inhibition: 3920 nM
For compound 4 the middle estimate is 9.8-fold (0.99 log units) below the measured one; measured number above the stated range.
By their numbers in this assay, from the lowest: compound 2; then compound 1; then compounds 4 and 3 (each within the scatter of the next).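

In this assay, 4-(trifluoromethyl)phenyl on the amide-type nitrogen performs much like 2,3-dimethylphenyl (a 1.5-fold lower number from compound 3 to compound 4 (0.18 log units; within the scatter)), so removing 2,3-dimethylphenyl does not by itself bring a clear gain. The new group remains far from 2,3-dichlorophenyl (a 62-fold higher number from compound 2 to compound 4 (1.79 log units; beyond the scatter)) and also falls short of 2,4-dimethylphenyl (a 3.0-fold higher number from compound 1 to compound 4 (0.48 log units; beyond the scatter)). No measurement here explains these differences.

The compounds shown leave open how an unsubstituted phenyl group or a phenyl group carrying a single chlorine would compare. Going by these compounds, whether compound 2 owes its low number to chlorine itself or to having two chlorines therefore remains unknown.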